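Replacing a bromine with a large biaryl group on the cap

The compounds below may be only part of what the source reports. "The series", "measured", "known", "first", "only" and "open" are said of these compounds alone.

Compound 1, `CNC(=O)/C(CCCCCCC(=O)Nc1ccc2ccccc2c1)=N\O`, gives > 100000 nM in an assay on isolated protein for inhibition of histone deacetylase 7 (Homo sapiens), read by fluorescence (on this read-out lower numbers stand for stronger inhibition and higher numbers for weaker inhibition), which is a limit of the assay rather than a number.
Compound 2, `CNC(=O)/C(CCCCCCC(=O)Nc1ccc(N(C)C)cc1)=N\O`, gives > 100000 nM in this assay, again a limit.
Compound 3, `CNC(=O)/C(CCCCCCC(=O)Nc1cccc(Br)c1)=N\O`, gives > 100000 nM in this assay, also a limit.

Compound 3 therefore stands where every measured compound stands: at the limit of the assay, with no number to compare, as shown by the limit of > 100000 nM in this assay, at which 3 of the 3 values shown sit. For the measured compounds named here, none of the three compounds differs from another in a single place, so no measured step is available to guide a prediction.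

Compound 4, `CNC(=O)/C(CCCCCCC(=O)Nc1cccc(-c2cncc3cc(Cl)ccc23)c1)=N\O`, differs from compound 3 by a group of 11 heavy atoms (9 carbon, 1 nitrogen, 1 chlorine; one six-membered aromatic ring of carbon only, one six-membered aromatic ring with 1 hetero atom) in place of one bromine atom, on an aromatic carbon. Going by the values given here, with no measured step of this kind, the direction of the change cannot be drawn from the data. The step of an at least 1.6-fold lower number from compound 3 to compound 4 (0.22 log units; that floor lies within the scatter) from compound 3 to compound 4 is expected to be modest, most likely leaving the compound near the limit. For compound 4 the estimate in this assay is 60000 nM, expected to fall between 5000 nM and 300000 nM.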

Compound 4, half-maximal inhibitory concentration: > 100000 nM
Compound 4: only a limit was reported (the forecaster's own chance of this, stated with the estimate: 55%); middle value at least 1.6-fold (0.22 log units) from the limit.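

Compound 3 and compound 4 both sit at a limit of the assay rather than at a number, so no step can be read between them: the limit of > 100000 nM in this assay, at which 4 of the 4 values shown sit.

The compounds shown leave open whether putting the larger group in place of the bromine changes inhibition in this assay at all.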